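A few compounds are considered here, and "the series" means these few. Any claim that something is new, unique, unknown or untested is made for them only; others in the source may bear on it.

In a functional assay on BV-2 cells (Mus musculus) for inhibition, read by Griess assay, with a stated time of 24 h (on this read-out higher numbers stand for weaker inhibition and lower numbers for stronger inhibition), compound 3 `C=C(C)[C@@H]1CC[C@](C)(O)[C@H]1/C=C/C(C)=C/[C@@H]1C[C@@]2([C@H](OC)O1)[C@H](CCCO)/C(=C(/C)C=O)CC[C@]2(C)O` gives > 10000 nM as a limit, not a number. Compound 1 `C=C(C)[C@@H]1CC[C@](C)(O)[C@H]1/C=C/C(C)=C/[C@@H]1C[C@@]23[C@H](OCCC[C@@H]2/C(=C(/C)C=O)CC[C@]3(C)O)O1` gives > 10000 nM as a limit too. Compound 2 `C=C(C)[C@H]1CC[C@@](C)(O)[C@@H]1/C=C/C(C)=C/[C@@H]1C[C@@]23[C@H](OCCC[C@@H]2/C(=C(\C)C=O)CC[C@]3(C)O)O1` gives > 10000 nM as a limit too. Compound 4 `C=C(C)[C@@H]1CC[C@](C)(O)[C@H]1/C=C/C(C)=C/[C@@H]1C[C@@]2([C@H](OC)O1)[C@H](CCCO)/C(=C(\C)C=O)CC[C@]2(C)O` has yet to be measured, and the change from compound 3 is this: the two compounds have the same atoms and bonds and differ only in configuration as drawn: 1 of 11 stereo elements differ; a double bond is drawn Z in compound 3 and E in compound 4 while nothing leaves and nothing enters. The nearest measured step is a step that the two limits leave unreadable from compound 1 to compound 2 and it has no readable size, resting on the fact that compounds 1 and 2 differ only in the configuration as drawn and on the limit of > 10000 nM in this assay, at which 3 of the 3 values shown sit, alone. In this assay no step beyond the scatter is therefore expected, and no direction can be argued. The expected step is a step that the limit leaves unreadable from compound 3 to compound 4 and it carries little weight. Compound 4 is estimated at 14000 nM within a range of 6000 nM to 40000 nM and will probably be reported only as a limit.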

Compound 4, half-maximal inhibitory concentration: > 10000 nM
Compound 4 was reported as a limit; the forecaster's own chance of this, stated with the estimate: 85%; the middle value is on the limit's open side.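

Among the compounds shown here, compound 3 and compound 4 both stand only as limits, not numbers, and no step between them can be read. The compounds shown leave open whether the configuration of this double bond bears on inhibition at all.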